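A few compounds are considered here, and "the series" means these few. Any claim that something is new, unique, unknown or untested is made for them only; others in the source may bear on it.

Three compounds of this series have numbers in a functional assay on T47D cells (Homo sapiens) for cytotoxicity, read by CCK-8 assay and cell counting, with a stated time of 2 days (on this read-out higher numbers stand for weaker inhibition and lower numbers for stronger inhibition), so far: compound 1 `Oc1cccc(-c2cc(-c3ccc(Cl)cc3)nc(-c3ccccn3)c2)c1` gives 13900 nM, compound 2 `Oc1ccc(-c2cc(-c3ccccc3)nc(-c3ccccc3Cl)c2)cc1` gives 5460 nM, and compound 3 `Oc1cccc(-c2cc(-c3ccccc3)nc(-c3ccccc3Cl)c2)c1` gives 2920 nM. Compound 2 stands second highest of the three; its nearest neighbour is compound 3, reached by a 1.9-fold lower number from compound 2 to compound 3 (0.27 log units; within the scatter), while compound 1 sits a larger gap higher, beyond the scatter. Compound 4 `Oc1ccc(-c2cc(-c3ccsc3)nc(-c3ccccc3Cl)c2)cc1` differs from compound 2 by thiophen-3-yl in place of phenyl on an aromatic carbon. Among the measured compounds shown here, no measured step touches this group: the only measured step, a 1.9-fold lower number from compound 2 to compound 3 (0.27 log units; within the scatter), alters the hydroxyphenyl instead. Hence no step beyond the scatter is expected in this assay, and the change is estimated as a 1.1-fold lower number from compound 2 to compound 4 (0.04 log units; within the scatter). Compound 4 is therefore expected to give about 5000 nM, within 1800 nM to 14000 nM.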

Compound 4, half-maximal inhibitory concentration: 6110 nM
Compound 4: the middle estimate sits 1.2-fold (0.09 log units) below what was measured; measured number inside the range.
By their numbers in this assay, from the lowest: compounds 3, 2 and 4 (each within the scatter of the next, the first and the last beyond it); then compound 1.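

In this assay, among the compounds shown here, thiophen-3-yl in place of phenyl next to the ring nitrogen gives a 1.1-fold higher number from compound 2 to compound 4 (0.05 log units; within the scatter), the first reading at this position. A five-membered aromatic ring with one sulfur atom therefore stays within the scatter of the six-membered carbon ring on this core. No supporting data bear on this result.

On these data alone, whether an amine, a carboxylic acid or a longer chain at this position would also stay within the scatter remains open. So does whether thiophen-3-yl behaves alike alongside the 3-hydroxyphenyl group of compound 3.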